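Pyrimidinyl exchange on the thiourea series: compound 3

This account rests on a few compounds, and the source may have more. Where it says the series, first, only, none or still open, it means among the compounds named here.

For the measured compounds named here, compound 2 `Cc1cc(C)nc(NC(=S)NC(=O)c2c(-c3ccc(Cl)cc3Cl)noc2C)n1` stands lowest of the two numbers so far in a functional assay on the whole organism for inhibition, with Digitaria ciliaris as the target, with a stated time of 72 h, tested at 100 mg/L (a higher number here means more inhibition of growth at the concentration tested, a lower number less inhibition of growth), where compound 2 gives 61.4%. Going by the values given here, its only neighbour is compound 1 `COc1cc(Cl)nc(NC(=S)NC(=O)c2c(-c3ccc(Cl)cc3Cl)noc2C)n1`, which in this assay gives 62.2%; the step of a number 0.8 percentage points lower from compound 1 to compound 2 (within the scatter) lies within the scatter, so no order between the two is claimed. Compound 3 `COc1cc(OC)nc(NC(=S)NC(=O)c2c(-c3ccc(Cl)cc3Cl)noc2C)n1` is not yet measured and differs from compound 2 by 4,6-dimethoxypyrimidin-2-yl in place of 4,6-dimethylpyrimidin-2-yl on an amide-type nitrogen. Among the compounds with values here, the single measured step bearing on this exchange is the one from compound 1 to compound 2, which also swapped one heteroaryl group for another on the same amide-type nitrogen and came out within the scatter. On that basis no step beyond the scatter is expected in this assay, in either direction. The expected step, a number 0.6 percentage points higher from compound 2 to compound 3 (within the scatter), is estimated to stay within the scatter. Compound 3 is therefore expected at 62%, within 45% to 78%.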

Compound 3, percent growth inhibition at one concentration: 65.9%
Compound 3: the middle estimate sits 3.9 percentage points below what was measured, and the stated range covers the measured number.
By their numbers in this assay, from the lowest: compounds 2, 1 and 3 (each within the scatter of the next).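

Replacing both methyl groups of compound 2 with methoxy on the pyrimidine gives a number 4.5 percentage points higher from compound 2 to compound 3 (within the scatter) in this assay, and methoxy in place of chloro on an aromatic carbon gives a number 3.7 percentage points higher from compound 1 to compound 3 (within the scatter) in the same assay. Compounds 1, 2 and 3 therefore cannot be ordered, and on the amide-type nitrogen of this thiourea series the methyl, chloro and methoxy pyrimidine substituents shown here, including the added hydrogen-bond acceptors of 4,6-dimethoxypyrimidin-2-yl, move the result by no more than the scatter. Nothing measured here speaks to any cause.

From the compounds shown here alone, it remains open whether a pyrimidin-2-yl carrying an amino group or a plain phenyl on this nitrogen would leave this narrow band. Going by these compounds, the effect of replacing the thiocarbonyl with a carbonyl also remains open.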